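The source may hold more compounds than are shown below. What is called first, only, known or untested is meant among the compounds shown, and "the series" means these compounds.

The measurements come from a functional assay on DLD-1 cells (Homo sapiens) for antiproliferative activity, read by CellTiter-Glo, with a stated time of 72 h; a lower number here means a stronger inhibitor, a higher number a weaker inhibitor.

Compound 1 `CC1CCN(C2CCN(S(=O)(=O)c3cnc(Cl)s3)CC2)CC1` gives 1800 nM.
Compound 2 `CCc1ccc(S(=O)(=O)N2CCC(N3CCC(C)CC3)CC2)cc1` gives > 5000 nM, which is a limit of the assay rather than a number.
Compound 3 `CC1CCN(C2CCN(S(=O)(=O)c3ccc(F)cc3F)CC2)CC1` gives 102 nM.

Compound 3 stands lowest of the two numbers available; its nearest neighbour is compound 1, and that gap is an 18-fold lower number from compound 1 to compound 3 (1.25 log units; beyond the scatter). Compound 4 `CC1CCN(C2CCN(S(=O)(=O)c3ccc(Cl)c(Cl)c3)CC2)CC1` has not been measured. It differs from compound 3 in one place: 3,4-dichlorophenyl in place of 2,4-difluorophenyl on a sulfonyl sulfur. All three measured steps change exactly this group on the sulfonyl sulfur, so all three bear on the new step. Two of them were large, an 18-fold lower number from compound 1 to compound 3 (1.25 log units; beyond the scatter) and an at least 49-fold lower number from compound 2 to compound 3 (1.69 log units; beyond the scatter), while the third, an at least 2.7-fold higher number from compound 1 to compound 2 (0.44 log units; beyond the scatter), can only be given as a bound because of the limit of > 5000 nM in this assay, at which 1 of the 3 values shown sits. Together they show that swapping this group moves the number a great deal in either direction, and that the 2,4-difluorophenyl of compound 3 gave by far the lowest number. Among the measured compounds shown here, the 3,4-dichlorophenyl of compound 4 has no close counterpart among the measured groups, so the estimate is uncertain, but a step to a higher number is expected, a 5.9-fold higher number from compound 3 to compound 4 (0.77 log units; beyond the scatter). Compound 4 is therefore estimated at 600 nM, within a range from 120 nM to 3500 nM in this assay.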

Compound 4, half-maximal inhibitory concentration: 2.9 nM
Beside the measured number, compound 4's estimate is 210-fold (2.32 log units) above it; the measured number lies below the stated range.
By their numbers in this assay, from the lowest: compound 4; then compound 3; then compound 1. At a limit, above all of these: compound 2.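

In this assay, among the compounds shown here, the group on the sulfonyl sulfur can lower the number far more than the earlier compounds showed: replacing 2,4-difluorophenyl with 3,4-dichlorophenyl, which has the same count of heavy atoms and no hydrogen-bond donors or acceptors, gives a 35-fold lower number from compound 3 to compound 4 (1.55 log units; beyond the scatter). The gaps to the two weaker groups are wider still, with a 620-fold lower number from compound 1 to compound 4 (2.79 log units; beyond the scatter) and an at least 1700-fold lower number from compound 2 to compound 4 (3.23 log units; beyond the scatter), so this one position spans a very broad range of values within the four compounds. Compound 2 stands at a limit, so the second of these gaps is only a bound: the limit of > 5000 nM in this assay, at which 1 of the 4 values shown sits.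

Fluorine gives way to chlorine in the same step in which the substituents change their places on the ring, so the compounds shown cannot separate these two changes; a 3,4-difluorophenyl or a 2,4-dichlorophenyl group would address that directly. They also leave open how the number would respond to an amine or a carboxylic acid on this ring, and to any change elsewhere in the shared core.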